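Swapping the sulfonyl aryl group in a quinoline sulfone series

This account rests on a few compounds, and the source may have more. Where it says the series, first, only, none or still open, it means among the compounds named here.

Measured compounds:
compound 1, `Cc1ccc(S(=O)(=O)c2cnc3cc(Cl)ccc3c2N2CCC(C)CC2)cc1F`: 85%
compound 2, `CC1CCN(c2c(S(=O)(=O)c3cc(F)cc(F)c3)cnc3c(F)cccc23)CC1`: 9%
compound 3, `NS(=O)(=O)N1CCN(c2c(S(=O)(=O)c3cc(F)cc(F)c3)cnc3cc(F)ccc23)CC1`: 6.4%

In an assay on isolated protein for displacement of a labelled ligand from metabotropic glutamate receptor 5 (Homo sapiens), with a stated time of 60 min, tested at 1 uM (a higher number here means more inhibition at the concentration tested (going by the name of the read-out), a lower number less inhibition), compound 1 gives 85%, the highest of the three numbers. Compound 2 lies lower and compound 3 lies furthest away, both gaps well beyond the scatter. Compounds 2 and 3 differ from compound 1 in more than one place at once, so no single change can be read off from them.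

Compound 4, `CC1CCN(c2c(S(=O)(=O)c3cc(Cl)cc(Cl)c3)cnc3cc(Cl)ccc23)CC1`, has not yet been measured in this assay. It differs from compound 1 in one place: 3,5-dichlorophenyl in place of 3-fluoro-4-methylphenyl on a sulfonyl sulfur. For the measured compounds named here, no measured pair shows this change alone.

Going by the values given here, compound 2 gives 9% and compound 3 gives 6.4%; these are the only other compounds with a different aryl group on the sulfonyl sulfur, though both also differ elsewhere. On that basis the expected step is a loss, of uncertain size, a number 45 percentage points lower from compound 1 to compound 4 (beyond the scatter). Compound 4 is expected to give 40%, within a range from 8% to 80%.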

Compound 4, a percentage reported as inhibition, at one concentration (the size of the read-out at that concentration, not a potency): 93%
Beside the measured number, compound 4's estimate is 53 percentage points below it; the measured number lies above the stated range.
By their numbers in this assay, from the lowest: compounds 3 and 2 (each within the scatter of the next); then compounds 1 and 4 (each within the scatter of the next).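

In this assay, placing 3,5-dichlorophenyl in place of 3-fluoro-4-methylphenyl on a sulfonyl sulfur gives a number 8 percentage points higher from compound 1 to compound 4 (within the scatter). For the compounds shown here, this is the first single change read at this position, and it shows that, on the core of compound 1, one aryl group can replace the other with no loss in the read-out. Nothing at hand gives a reason for this outcome.

From the compounds shown here alone, whether the low numbers of compound 2 and compound 3 come from their sulfonyl aryl group or from their other differences stays open: each differs from compound 1 in more than one place. Also open, going by these compounds, is how the position would respond to a phenyl ring carrying an amine or a carboxylic acid, or to a saturated ring such as cyclohexyl.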